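This account rests on a few compounds, and the source may have more. Where it says the series, first, only, none or still open, it means among the compounds named here.

Working notes on the series. The shared core is that of compound 1 `O=S(=O)(/C=C/c1ccc(O)c(O)c1)CC1CC1`, and the variation lies on a saturated chain carbon bound to a sulfonyl sulfur. In a functional assay, read by fluorescence and spectrophotometry, with a stated time of 1 h (a higher number here means that more compound is needed for the effect, a lower number that less compound is needed), compound 1 gives 10500 nM. Compound 2 `O=S(=O)(/C=C/c1ccc(O)c(O)c1)CC1CCCO1` carries oxolan-2-yl in place of cyclopropyl at that position; in this assay compound 2 gives 10500 nM, and the step of no change at the digits printed from compound 1 to compound 2 (within the scatter) is flat within the scatter. For the measured compounds named here, compound 1 therefore stands level with compound 2 on the numbers so far.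

Compound 3 `C=CCCCCCS(=O)(=O)/C=C/c1ccc(O)c(O)c1` is not yet measured. Its difference from compound 1 is hex-5-en-1-yl in place of cyclopropyl on a saturated chain carbon bound to a sulfonyl sulfur. Going by the values given here, the only measured step bearing on this position is the one from compound 1 to compound 2, which showed no change; the entering group here has no ring, unlike either group measured, so how far that flat result carries is open. The step to compound 3 is expected to be no change at the digits printed from compound 1 to compound 3 (within the scatter), none beyond the scatter. For compound 3 the estimate in this assay is 10500 nM, within a range from 4000 nM to 30000 nM.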

Compound 3, half-maximal effective concentration: 7100 nM
Compound 3: the middle estimate sits 1.5-fold (0.17 log units) above what was measured, within the range that was stated.
By their numbers in this assay, from the lowest: compounds 3, 1 and 2 (each within the scatter of the next).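

In this assay the open-chain hex-5-en-1-yl on a saturated chain carbon bound to a sulfonyl sulfur stays within the scatter of both ring-bearing groups, with a 1.5-fold lower number from compound 1 to compound 3 (0.17 log units; within the scatter) and a 1.5-fold lower number from compound 2 to compound 3 (0.17 log units; within the scatter). The flat result at this position therefore now extends to a group with no ring, 6 heavy atoms against the 3 of cyclopropyl, and a double bond outside aromatic rings, so among these three compounds neither change moves the number beyond the scatter. No supporting measurement bears on the reason for this flat result.

Still open, on these data alone, is whether an amine or a carboxylic acid at this position would move the number beyond the scatter. Also open, as far as these compounds go, is whether plain hexyl or a longer chain would do so.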